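The compounds below may be only part of what the source reports. "The series", "measured", "known", "first", "only" and "open" are said of these compounds alone.

Compound 2 `CC(=O)Nc1cc(-c2ccc(OC[C@@H](N)CC(C)C)c(F)c2)ccn1` gives 1.6 nM in an assay on HEK293F cells for inhibition of AP2-associated protein kinase 1 (Homo sapiens), read by Western blot, with a stated time of 3 h (on this read-out higher numbers stand for weaker inhibition and lower numbers for stronger inhibition), the second highest of three numbers. Its nearest neighbour is compound 3 `COC(=O)Nc1cc(-c2ccc(OC[C@@](C)(N)CC(C)C)c(C)c2)ccn1`, which in this assay gives 0.8 nM; these two compounds differ in more than one place and their values lie within the scatter of each other. Furthest away is compound 1 `CC(=O)Nc1cc(-c2ccc(OC[C@@](C)(N)CC(C)C)c(F)c2)ccn1`, which in this assay gives 3.7 nM; the one single-point step so far, a 2.3-fold lower number from compound 1 to compound 2 (0.36 log units; beyond the scatter), concerns the saturated chain carbon bound to the ether oxygen and not the aromatic ring.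

Compound 4 `CC(=O)Nc1cc(-c2ccc(OC[C@@H](N)CC(C)C)c(OC(F)(F)F)c2)ccn1` is not yet measured. It differs from compound 2 by trifluoromethoxy in place of fluoro on an aromatic carbon. For the measured compounds named here, no measured step touches this position, so the step from compound 1 to compound 2 offers no direct guide, and the change is judged only by its size. The author therefore expects a step of a 1.3-fold higher number from compound 2 to compound 4 (0.10 log units; within the scatter) for compound 4, not beyond the scatter in either direction. Compound 4 is estimated at 2 nM in this assay, with a range from 0.7 nM to 6 nM.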

Compound 4, half-maximal inhibitory concentration: 0.45 nM
Compound 4: middle estimate off by 4.4-fold (0.65 log units), on the high side; the whole stated range lies above it.
By their numbers in this assay, from the lowest: compounds 4, 3 and 2 (each within the scatter of the next, the first and the last beyond it); then compound 1.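

In this assay this position, on an aromatic carbon ortho to a (2-amino-4-methylpentyl)oxy group, proves responsive: trifluoromethoxy in place of fluoro gives a 3.6-fold lower number from compound 2 to compound 4 (0.55 log units; beyond the scatter) in this single pair. The entering group has five heavy atoms against one and brings one hydrogen-bond acceptor, yet the number falls rather than rises, so at this position a larger group does not by itself give weaker inhibition. Nothing available explains this result.

The compounds shown leave open whether methoxy, trifluoromethyl or chloro at this position would give a similar step, and so which part of the trifluoromethoxy group goes with the lower number. Also open, as far as these compounds go, is whether the same exchange would give a like step on the 1-amino-1,3-dimethylbutyl chain of compound 1.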